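A few compounds are considered here, and "the series" means these few. Any claim that something is new, unique, unknown or untested is made for them only; others in the source may bear on it.

Going by the values given here, in a functional assay on the whole organism for inhibition, with Rattus norvegicus as the target (on this read-out lower numbers stand for an effect already at smaller amounts and higher numbers for an effect only at larger amounts of compound), compound 2 `CCc1ccc(CC(C)(Oc2ccc(C(C)C)cc2)C(=O)O)cc1` gives 0.1 mg/kg, the lowest number so far. Compound 3 `CCCCc1ccc(CC(C)(Oc2ccc(C(C)C)cc2)C(=O)O)cc1` gives 1 mg/kg. Compound 1 `CC(C)c1ccc(OC(C)(Cc2ccccc2)C(=O)O)cc1` gives > 10 mg/kg, which is a limit of the assay and not a number. The measured changes are both on an aromatic carbon: ethyl gave an at least 100-fold lower number from compound 1 to compound 2 (2.00 log units; beyond the scatter), and butyl gave an at least 10-fold lower number from compound 1 to compound 3 (1.00 log units; beyond the scatter). Compound 4 `CCc1ccc(CC(C)(Oc2ccc(C(C)C)cc2)C(=O)NS(=O)(=O)C(F)(F)F)cc1` differs elsewhere, with ((trifluoromethyl)sulfonyl)amino in place of hydroxy on a carbonyl carbon. Among the compounds with values here, no measured step touches this carboxy group, so the guidance is only indirect. Still, a 10-fold higher number from compound 2 to compound 3 (1.00 log units; beyond the scatter) shows how readily the number can rise from this low point. The expected change in this assay is therefore modest and upward, a 3.0-fold higher number from compound 2 to compound 4 (0.48 log units; beyond the scatter). For compound 4, the estimated value is 0.3 mg/kg, with an expected range of 0.05 mg/kg to 2 mg/kg.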

Compound 4, dose for half-maximal effect: > 10 mg/kg
Compound 4: no number, only a limit; the forecaster's own chance of this, stated with the estimate: 15%; at least 33-fold (1.52 log units) between middle value and limit.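

Going by these compounds alone, at this position, where the earlier compounds gave no reading, ((trifluoromethyl)sulfonyl)amino in place of hydroxy on a carbonyl carbon gives an at least 100-fold higher number from compound 2 to compound 4 (2.00 log units; beyond the scatter) in this assay. The number therefore responds strongly to a change at this carbonyl carbon. The value of compound 4 is a limit, so the true size of the step stays unknown: the limit of > 10 mg/kg in this assay, at which 2 of the 4 values shown sit.

The compounds shown leave open how a smaller group on the same carbonyl carbon, such as an amine or a methoxy group, would read out. They also leave open whether any replacement for hydroxy here can keep the number low.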